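The source may hold more compounds than are shown below. What is called first, only, known or untested is meant among the compounds shown, and "the series" means these compounds.

Compound 1 `COc1cccc(-n2cc(COc3cccc(NC(=O)Nc4ccc(Cl)c(C(F)(F)F)c4)c3)nn2)c1` gives 8570 nM in a toxicity assay on MRC5 cells (Homo sapiens) for inhibition, read by MTT assay, with a stated time of 72 h; a higher number here means a weaker inhibitor, a lower number a stronger inhibitor.
Compound 2 `N#Cc1ccccc1-n1cc(COc2cccc(NC(=O)Nc3ccc(Cl)c(C(F)(F)F)c3)c2)nn1` gives 17500 nM in this assay.
Compound 3 `N#Cc1cccc(-n2cc(COc3cccc(NC(=O)Nc4ccc(Cl)c(C(F)(F)F)c4)c3)nn2)c1` gives 2960 nM in this assay.

Compound 3 stands lowest of the three numbers: the step of a 2.9-fold lower number from compound 1 to compound 3 (0.46 log units; beyond the scatter) and the step of a 5.9-fold lower number from compound 2 to compound 3 (0.77 log units; beyond the scatter) both lie beyond the scatter, so compound 3 is the strongest inhibitor among the measured set. Compound 4 `CC(C)c1cccc(-n2cc(COc3cccc(NC(=O)Nc4ccc(Cl)c(C(F)(F)F)c4)c3)nn2)c1` has not yet been measured. It differs from compound 3 in one place: isopropyl in place of cyano on an aromatic carbon. The measured step that bears most directly on this change is the one in which the same position carried methoxy rather than cyano, a 2.9-fold lower number from compound 1 to compound 3 (0.46 log units; beyond the scatter), which shows that taking the nitrile away from this position and putting another group there raised the number modestly. The step of a 2.0-fold higher number from compound 1 to compound 2 (0.31 log units; beyond the scatter) and the step of a 5.9-fold lower number from compound 2 to compound 3 (0.77 log units; beyond the scatter) concern the position of the nitrile rather than its replacement, so they inform this change only loosely. On that basis compound 4 is expected to give a modestly higher number than compound 3, roughly a 2.2-fold higher number from compound 3 to compound 4 (0.34 log units; beyond the scatter). The estimate for compound 4 is 6500 nM, expected to fall between 2500 nM and 16000 nM.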

Compound 4, half-maximal inhibitory concentration: 21400 nM
Compound 4: middle estimate off by 3.3-fold (0.52 log units), on the low side; the whole stated range lies below it.
By their numbers in this assay, from the lowest: compound 3; then compound 1; then compounds 2 and 4 (each within the scatter of the next).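

Taking the nitrile from this aromatic carbon and putting isopropyl there in this assay gives a 7.2-fold higher number from compound 3 to compound 4 (0.86 log units; beyond the scatter), so a second replacement of the nitrile, beyond the methoxy of the earlier compounds, also raises the number. Isopropyl and methoxy are also separated at this same carbon, with a 2.5-fold higher number from compound 1 to compound 4 (0.40 log units; beyond the scatter), which places the three groups in the order cyano, methoxy, isopropyl from the lowest number to the highest, each step lying beyond the scatter. The 3-isopropylphenyl of compound 4 cannot be told apart from the 2-cyanophenyl of compound 2, as a 1.2-fold higher number from compound 2 to compound 4 (0.09 log units; within the scatter) lies within the scatter, and nothing shown here explains why these groups rank as they do.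

With only three groups at this carbon, the compounds shown leave open whether the number follows the size of the group, the presence of the nitrile or something else. An amine, a carboxylic acid, a methyl or a longer chain at the same carbon would test whether any group gives a number lower than that of the nitrile in compound 3.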